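The source may report more compounds than this note shows. Statements on the series, on what has been measured and on what is new or still open speak of the compounds shown alone.

Working notes on the series. In a functional assay on MCF7 cells (Homo sapiens) for cytotoxicity, read by sulforhodamine B assay, with a stated time of 72 h (a lower number here means a stronger inhibitor, a higher number a weaker inhibitor), compound 1 `Cc1cc(NS(=O)(=O)c2ccc(NCc3coc4ccccc4c3=O)cc2)no1` gives 34500 nM. Compound 2 `NS(=O)(=O)c1ccc(NC2=NC(=O)/C(=C\c3coc4ccccc4c3=O)S2)cc1` gives 8910 nM, a lower number than compound 1 shows, with a gap beyond the scatter. Compound 3 `O=C1/C(=C/c2coc3ccccc3c2=O)N=C(c2ccc(Cl)cc2)N1c1ccc(S(=O)(=O)Nc2nccs2)cc1` reads > 100000 nM, and this is a limit, not a number. Of the two true numbers in the series, compound 1 therefore holds the higher.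

Compound 4 `Cc1cc(C)nc(NS(=O)(=O)c2ccc(NCc3coc4ccccc4c3=O)cc2)n1` is still unmeasured. It keeps the core of compound 1 and has 4,6-dimethylpyrimidin-2-yl in place of 5-methyl-1,2-oxazol-3-yl on a sulfonamide nitrogen. Among the compounds with values here, no measured pair isolates this change, so the only anchor is compound 1 at 34500 nM, the sole measured compound with the same core. In this assay no step beyond the scatter is expected. The estimated change is a 1.2-fold lower number from compound 1 to compound 4 (0.06 log units; within the scatter), which is expected to stay within the scatter. For compound 4 the estimated value is 30000 nM, with an expected range from 10000 nM to 90000 nM.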

Compound 4, half-maximal inhibitory concentration: 93600 nM
Compound 4: middle estimate off by 3.1-fold (0.49 log units), on the low side, outside the stated range (above it).
By their numbers in this assay, from the lowest: compound 2; then compound 1; then compound 4. At a limit, above all of these: compound 3.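

In this assay, within the data shown here, the group on the sulfonamide nitrogen is not a silent position: 4,6-dimethylpyrimidin-2-yl in place of 5-methyl-1,2-oxazol-3-yl gives a 2.7-fold higher number from compound 1 to compound 4 (0.43 log units; beyond the scatter) and is the first step that isolates a single change. With the core of compound 1 held fixed, this swap moves the number towards weaker inhibition, so the substituent at this place does register in the read-out. Compound 4 now reads near the top of the measurable range, leaving little room to resolve any further weakening on this core: the limit of > 100000 nM in this assay, at which 1 of the 4 values shown sits.

A single step cannot separate the effect of ring size from that of the two added methyl groups. As far as these compounds go, whether phenyl or unsubstituted pyrimidin-2-yl on the same nitrogen would read lower than compound 1 stays open.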